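Replacing hydroxyphenyl by dichlorophenyl: expected shift for compound 4

The compounds below may be only part of what the source reports. "The series", "measured", "known", "first", "only" and "open" are said of these compounds alone.

Three compounds share one core and differ only at the aryl end of the chain. In an assay on isolated protein for displacement of a labelled ligand from melanin-concentrating hormone receptor 1 (Homo sapiens) (on this read-out lower numbers stand for stronger inhibition and higher numbers for weaker inhibition), compound 1 `CCCc1cc(N)c2cc(NC(=O)/C=C/c3ccc(C(C)(C)C)cc3)ccc2n1` gives 22 nM, compound 2 `CCCc1cc(N)c2cc(NC(=O)/C=C/c3ccc(Br)cc3)ccc2n1` gives 4 nM and compound 3 `CCCc1cc(N)c2cc(NC(=O)/C=C/c3ccc(O)cc3)ccc2n1` gives 1100 nM. Compound 3 stands highest of the three and is the weakest binder here: a 50-fold higher number from compound 1 to compound 3 (1.70 log units; beyond the scatter) and a 280-fold higher number from compound 2 to compound 3 (2.44 log units; beyond the scatter), both beyond the scatter. Compound 4 `CCCc1cc(N)c2cc(NC(=O)/C=C/c3ccc(Cl)c(Cl)c3)ccc2n1` carries 3,4-dichlorophenyl in place of 4-hydroxyphenyl on a double-bonded chain carbon bound to a double-bonded chain carbon. The steps bearing on this swap are those two, read backwards: hydroxy gave far higher numbers than tert-butyl or bromo, the bromo case being the larger. Exchanging hydroxy for the two chlorines is therefore expected to produce a large fall in this assay for compound 4, about a 220-fold lower number from compound 3 to compound 4 (2.34 log units; beyond the scatter). Compound 4 is estimated at 5 nM, within 1.5 nM to 20 nM.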

Compound 4, half-maximal inhibitory concentration: 60 nM
Beside the measured number, compound 4's estimate is 12-fold (1.08 log units) below it, and the stated range ends below it.
By their numbers in this assay, from the lowest: compound 2; then compound 1; then compound 4; then compound 3.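

In this assay, 3,4-dichlorophenyl recovers much of the binding lost with 4-hydroxyphenyl (an 18-fold lower number from compound 3 to compound 4 (1.26 log units; beyond the scatter)), yet it does not match 4-bromophenyl (a 15-fold higher number from compound 2 to compound 4 (1.18 log units; beyond the scatter)). Halogen on the ring is thus no guarantee of the lowest number at this position: compound 2 and compound 4 stay clearly apart. No available data explain these differences. On these data alone, whether a single chlorine, as in 4-chlorophenyl, would read closer to compound 2 or to compound 4 remains open. As far as these compounds go, how an amine or a carboxylic acid on this ring would read also stays open.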